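The source may report more compounds than this note shows. Statements on the series, on what has been measured and on what is new or still open speak of the compounds shown alone.

Compound 1 `CCOc1ccc(F)c(-c2ccc(OCCCC(=O)O)cc2)c1` and compound 2 `O=C(O)CCCOc1ccc(-c2cc(Oc3ccccc3)ccc2F)cc1` share the same core and differ only in the group carried on one oxygen. In a functional assay on isolated protein for agonist activity at Free fatty acid receptor 1 (Homo sapiens), read by HTRF and inositol phosphate accumulation, with a stated time of 60 min (a higher number here means that more compound is needed for the effect, a lower number that less compound is needed), compound 1 gives 3190 nM, and compound 2 gives 3590 nM. The step of a 1.1-fold higher number from compound 1 to compound 2 (0.05 log units; within the scatter) shows that putting phenyl in place of ethyl on that oxygen leaves the number essentially where it was. Numerically compound 2 carries the higher of the two values, but because a 1.1-fold higher number from compound 1 to compound 2 (0.05 log units; within the scatter) is within the scatter the two compounds cannot be told apart on these data.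

Compound 3 `O=C(O)CCCOc1ccc(-c2cc(Oc3cccc(F)c3)ccc2F)cc1` has not yet been measured. It differs from compound 2 by fluoro in place of hydrogen on an aromatic carbon, the place being on an aromatic carbon of a six-membered aromatic ring of carbon only, meta to a large group; read one bond further out, the phenoxy becomes a 3-fluorophenoxy. Among the compounds with values here, no measured step touches this outer ring directly; the only step available, a 1.1-fold higher number from compound 1 to compound 2 (0.05 log units; within the scatter), is a larger change at this oxygen and stayed within the scatter. The added fluoro is expected to move this assay little, so the estimated step of a 1.2-fold lower number from compound 2 to compound 3 (0.08 log units; within the scatter) is none beyond the scatter. Compound 3 is estimated at 3000 nM, within a range from 1200 nM to 8000 nM.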

Compound 3, half-maximal effective concentration: 9460 nM
Estimate against measurement, compound 3: 3.2-fold (0.50 log units) below; the measured number lies above the stated range.
By their numbers in this assay, from the lowest: compounds 1 and 2 (each within the scatter of the next); then compound 3.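

In this assay, the outer ring of the phenoxy group turns out to matter: one fluoro on an aromatic carbon, meta to a large group, gives a 2.6-fold higher number from compound 2 to compound 3 (0.42 log units; beyond the scatter), a modest step but beyond the scatter. The much larger swap of ethyl for phenyl on the same oxygen had stayed within the scatter (a 1.1-fold higher number from compound 1 to compound 2 (0.05 log units; within the scatter)), so the size of a change says little here about the size of its effect. Set against the ethyl compound, 3-fluorophenyl in place of ethyl gives a 3.0-fold higher number from compound 1 to compound 3 (0.47 log units; beyond the scatter), so a step beyond the scatter appears at this oxygen only once the fluoro is on the ring, and nothing at hand explains why a single atom has this effect.

On these data alone, what stays open is whether the higher number belongs to fluoro itself or to any group at this place, which a chloro, a methyl or a methoxy there would help to separate. Also open, as far as these compounds go, is whether fluoro on another carbon of the same ring gives a similar step, or whether it leaves the number where compound 2 has it.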